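The source may hold more compounds than are shown below. What is called first, only, known or untested is meant among the compounds shown, and "the series" means these compounds.

Measured so far in a functional assay on KBVIN cells (Homo sapiens) for antiproliferative activity, read by sulforhodamine B assay, with a stated time of 3 days; a lower number here means that less compound is needed, a higher number that more compound is needed for the effect:
- compound 1, `CCC1=C(O)c2c(oc(-c3ccc(OC)cc3)cc2=O)C(CC)(CC)C1=O`: 0.68 uM
- compound 2, `CCC1=C(O)c2c(oc(-c3ccc(F)cc3)cc2=O)C(CC)(CC)C1=O`: 1.85 uM
- compound 3, `CCC1=C(O)c2c(oc(-c3ccc(C)cc3C)cc2=O)C(CC)(CC)C1=O`: 8.52 uM

Compound 3 gives the highest number of the three in this assay. The nearest is compound 2, with a 4.6-fold higher number from compound 2 to compound 3 (0.66 log units; beyond the scatter); the furthest is compound 1, with a 13-fold higher number from compound 1 to compound 3 (1.10 log units; beyond the scatter).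

Compound 4, `CCC1=C(O)c2c(oc(-c3cc(C)ccc3F)cc2=O)C(CC)(CC)C1=O`, is not yet measured. It differs from compound 3 at the aromatic carbon next to the ring oxygen: 2-fluoro-5-methylphenyl in place of 2,4-dimethylphenyl on an aromatic carbon.

Among the measured compounds shown here, two measured steps bear on this change. The step of a 2.7-fold higher number from compound 1 to compound 2 (0.43 log units; beyond the scatter) shows that a fluoro on the phenyl gives a modestly higher number than a methoxy. The step of a 4.6-fold higher number from compound 2 to compound 3 (0.66 log units; beyond the scatter) shows that the 2,4-dimethylphenyl gives a modestly higher number than the 4-fluorophenyl. Compound 4 carries one fluoro and one methyl, so a position between compound 2 and compound 3 is expected, that is a modest step downward from compound 3 in this assay, a 2.1-fold lower number from compound 3 to compound 4 (0.33 log units; beyond the scatter).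

Estimate for compound 4 in this assay: 4 uM, expected to fall between 1.5 uM and 11 uM.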

Compound 4, concentration for half-maximal effect: 3.24 uM
Compound 4: middle estimate off by 1.2-fold (0.09 log units), on the high side, and the stated range covers the measured number.
By their numbers in this assay, from the lowest: compound 1; then compounds 2 and 4 (each within the scatter of the next); then compound 3.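

In this assay, moving from the 2,4-dimethylphenyl to the 2-fluoro-5-methylphenyl on the aromatic carbon next to the ring oxygen recovers part of the gap to the other compounds (a 2.6-fold lower number from compound 3 to compound 4 (0.42 log units; beyond the scatter)), and a phenyl carrying two substituents is therefore not by itself tied to the number of compound 3. Compound 4 cannot be separated from compound 2 (a 1.8-fold higher number from compound 2 to compound 4 (0.24 log units; within the scatter)), while compound 1 with its 4-methoxyphenyl stays clearly apart (a 4.8-fold higher number from compound 1 to compound 4 (0.68 log units; beyond the scatter)). Nothing at hand explains these differences.

The fluoro and the methyl change together between compound 3 and compound 4, so the share of each in the step stays unresolved. On these data alone, how a dimethylamino group or a carboxylic acid on this phenyl would read in this assay also remains open.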